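This account rests on a few compounds, and the source may have more. Where it says the series, first, only, none or still open, it means among the compounds named here.

Measured in a functional assay on CCRF-CEM cells (Homo sapiens) for cytotoxicity; on this read-out lower numbers stand for stronger inhibition and higher numbers for weaker inhibition:
Compound 1 `Nc1ncnc2c1ncn2[C@@H]1C=C[C@H](CO)C1`: > 100000 nM, a limit
Compound 2 `OC[C@H]1C=C[C@@H](n2cnc3c(S)ncnc32)C1`: > 100000 nM, a limit

Compound 2 has no exact number, only the limit > 100000 nM. This is the limit of > 100000 nM in this assay, at which 2 of the 2 values shown sit, so neither measured compound has an exact value. Within the data shown here, the one measured step is a step that the two limits leave unreadable from compound 1 to compound 2, and it offers no size to carry forward.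

Compound 3 `OC[C@H]1C=C[C@@H](n2cnc3c(O)ncnc32)C1` changes the same place on compound 2: hydroxy in place of sulfanyl on an aromatic carbon, (hydroxy in place of sulfanyl on an aromatic carbon). The data show no exact value for any compound on this core, so the expectation rests on compound 2 at > 100000 nM, a limit. No step beyond the usual scatter is expected in this assay, in either direction. The estimated change is a number no higher from compound 2 to compound 3 (the limit leaves the size open). Compound 3 is estimated at 100000 nM, with an expected range of 50000 nM to 200000 nM.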

Compound 3, half-maximal inhibitory concentration: > 100000 nM
Compound 3: a limit, no number; the forecaster's own chance of this, stated with the estimate: 90%; the middle value sits exactly at the limit.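

In this assay, among these compounds, compound 3, like compound 1 and compound 2, carries only a limit and not a number, so no step among the three can be read: the limit of > 100000 nM in this assay, at which 3 of the 3 values shown sit.

The compounds shown leave open how strongly any of them acts on these cells, and whether amino, sulfanyl or hydroxy at this place makes any difference.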